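Benzyl ether variation in the antiproliferative series

The source may hold more compounds than are shown below. What is called first, only, known or untested is meant among the compounds shown, and "the series" means these compounds.

Measured compounds:
compound 1 `COc1ccc2c(=O)c(-c3cc(OC)c(OC)cc3OC)coc2c1` — 9400 nM
compound 2 `COc1cc(OC)c(-c2coc3cc(OCc4ccccc4C)ccc3c2=O)cc1OC` — 2000 nM

In a functional assay on U-251 cells (Homo sapiens) for antiproliferative activity, read by MTT assay, with a stated time of 24 h (on this read-out lower numbers stand for stronger inhibition and higher numbers for weaker inhibition), compound 1 gives 9400 nM. In this assay, within the data shown here, compound 2 gives 2000 nM, the lowest of the two numbers, and its only neighbour is compound 1. Among the measured compounds shown here, the single step within the pair is a 4.7-fold lower number from compound 1 to compound 2 (0.67 log units; beyond the scatter), a modest gain that came with the 2-methylphenyl group entering on the saturated chain carbon bound to an oxygen on the aromatic ring.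

Compound 3 `COc1cc(OC)c(-c2coc3cc(OCc4ccc(C(F)(F)F)cc4)ccc3c2=O)cc1OC` is not yet measured. It differs from compound 2 in one place: 4-(trifluoromethyl)phenyl in place of 2-methylphenyl on a saturated chain carbon bound to an oxygen on an aromatic ring. For the measured compounds named here, the one measured step bears on it only loosely, since it concerns adding the aryl group rather than changing its substituent, and no measured pair compares one substituted benzyl with another. The expectation is therefore a step no larger than the scatter, with direction uncertain, and the estimate for the change from compound 2 to compound 3 is no change at the digits printed from compound 2 to compound 3 (within the scatter). Compound 3 is estimated at 2000 nM, within a range from 700 nM to 6000 nM.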

Compound 3, half-maximal inhibitory concentration: 3750 nM
Beside the measured number, compound 3's estimate is 1.9-fold (0.27 log units) below it, and the stated range covers the measured number.
By their numbers in this assay, from the lowest: compounds 2 and 3 (each within the scatter of the next); then compound 1.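

In this assay, the exchange of 2-methylphenyl for 4-(trifluoromethyl)phenyl on the saturated chain carbon bound to an oxygen on an aromatic ring gives a 1.9-fold higher number from compound 2 to compound 3 (0.27 log units; within the scatter), so this first comparison of one substituted benzyl with another shows no difference that can be read beyond the scatter. The gain over hydrogen in that place now appears with a second aryl group, as a 2.5-fold lower number from compound 1 to compound 3 (0.40 log units; beyond the scatter), so compound 2 and compound 3 both stand apart from compound 1, and neither goes against this within the three compounds shown. No measurement on these compounds accounts for either step.

In this pair the substituent and its place on the phenyl ring change together, so the effect of the methyl or trifluoromethyl group cannot be separated from the effect of where it sits. Going by these compounds, it remains open whether the unsubstituted benzyl group, a longer chain between the oxygen and the phenyl ring, or a chain ending in an amine or a carboxylic acid would move the number beyond the scatter from compound 2.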